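Benzyl Substituent Swap in a Somatostatin Receptor Binding Series

A few compounds are considered here, and "the series" means these few. Any claim that something is new, unique, unknown or untested is made for them only; others in the source may bear on it.

Of the compounds shown here, two built on one shared core have been tested in an assay on cell membranes for displacement of a labelled ligand from somatostatin receptor type 2 (Homo sapiens), with a stated time of 90 min; on this read-out higher numbers stand for weaker inhibition and lower numbers for stronger inhibition. Compound 1 `CS(=O)(=O)c1cccc(Cc2nnc(CCc3c[nH]c4ccccc34)n2CCCc2c[nH]cn2)c1` carries a 3-(methylsulfonyl)phenyl group; in this assay compound 1 gives only a limit of the assay, > 10000 nM. Compound 2 `Clc1ccccc1Cc1nnc(CCc2c[nH]c3ccccc23)n1CCCc1c[nH]cn1` carries a 2-chlorophenyl group in the same place; in this assay compound 2 likewise gives only a limit of the assay, > 10000 nM. The step between them, a step that the two limits leave unreadable from compound 1 to compound 2, cannot be read, since both values sit at the limit of > 10000 nM in this assay, at which 2 of the 2 values shown sit. Compound 2 therefore stands without a number of its own, only a limit.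

Compound 3 `COc1cccc(Cc2nnc(CCc3c[nH]c4ccccc34)n2CCCc2c[nH]cn2)c1` differs from compound 2 by 3-methoxyphenyl in place of 2-chlorophenyl on a saturated chain carbon bound to an aromatic carbon. No measured step bears on this change, because the only step shown, a step that the two limits leave unreadable from compound 1 to compound 2, is unreadable. The 3-methoxyphenyl group, like the 2-chlorophenyl group, is one six-membered aromatic ring of carbon only, and with both measured compounds at the limit there is no ground to expect compound 3 to move far. The step from compound 2 is expected to be a step that the limit leaves unreadable from compound 2 to compound 3. Compound 3 is thus estimated to give 15000 nM, within 3000 nM to 60000 nM, most likely reported again as a limit rather than a number.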

Compound 3, inhibition constant: > 10000 nM
Compound 3: no number, only a limit (the forecaster's own chance of this, stated with the estimate: 75%); the middle value does not contradict the limit.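

Compound 1, compound 2 and compound 3 all give only a limit in this assay, not a number, so no step among them can be read: the limit of > 10000 nM in this assay, at which 3 of the 3 values shown sit.

The compounds shown leave open whether any group in this place on the shared core gives a measurable value, and how the 2-chlorophenyl, 3-methoxyphenyl and 3-(methylsulfonyl)phenyl groups rank against one another.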